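This account rests on a few compounds, and the source may have more. Where it says the series, first, only, none or still open, it means among the compounds named here.

Working notes on the series, read in a functional assay on B16-F0 cells (Mus musculus) for inhibition, read by CCK-8 assay, with a stated time of 48 h; on this read-out higher numbers stand for weaker inhibition and lower numbers for stronger inhibition. Of the compounds shown here, three on the shared core have numbers so far: compound 1 `COc1cc(-c2ccnc3cc(-c4ccc(C)c(C)c4)nn23)cc(OC)c1OC` gives 391 nM, compound 2 `COc1cc(-c2ccnc3cc(-c4ccc(C(F)(F)F)cc4)nn23)cc(OC)c1OC` gives 1770 nM, and compound 3 `COc1cc(-c2ccnc3cc(-c4ccc5ccn(C)c5c4)nn23)cc(OC)c1OC` gives 657 nM. The standing of compound 3 is set by two steps: a 1.7-fold higher number from compound 1 to compound 3 (0.23 log units; within the scatter), and a 2.7-fold lower number from compound 2 to compound 3 (0.43 log units; beyond the scatter). Its number is therefore not separated from that of compound 1, while it is separated from that of compound 2.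

Next is compound 4 `COc1cc(-c2ccnc3cc(-c4ccc(C(C)(C)C)cc4)nn23)cc(OC)c1OC`, with 4-(tert-butyl)phenyl in place of 1-methyl-1H-indol-6-yl on an aromatic carbon. All measured steps exchange the group on this same carbon, and the largest of them is a 4.5-fold higher number from compound 1 to compound 2 (0.66 log units; beyond the scatter). Compound 2, whose 4-(trifluoromethyl)phenyl is the closest measured group by name to 4-(tert-butyl)phenyl, sits at the high end with 1770 nM. Going by the values given here, no measured compound carries a tert-butyl group, so this comparison is only a loose guide. A small move toward a higher number in this assay is expected, probably not beyond the scatter. The expected step is a 1.4-fold higher number from compound 3 to compound 4 (0.14 log units; within the scatter). The estimated value for compound 4 is 900 nM, with an expected range from 350 nM to 2400 nM.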

Compound 4, half-maximal inhibitory concentration: > 10000 nM
Compound 4 gave a limit, no number; the forecaster's own chance of this, stated with the estimate: 3%; middle value at least 11-fold (1.04 log units) from the limit.
By their numbers in this assay, from the lowest: compounds 1 and 3 (each within the scatter of the next); then compound 2. At a limit, above all of these: compound 4.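

In this assay, compound 4 is known only as a limit of the assay, not as a number: the limit of > 10000 nM in this assay, at which 1 of the 4 values shown sits. Read against that limit, all three new steps lie beyond the scatter: an at least 15-fold higher number from compound 3 to compound 4 (1.18 log units; beyond the scatter), an at least 5.6-fold higher number from compound 2 to compound 4 (0.75 log units; beyond the scatter) and an at least 25-fold higher number from compound 1 to compound 4 (1.40 log units; beyond the scatter). The earlier compounds shown here showed this aromatic carbon carrying 3,4-dimethylphenyl, 1-methyl-1H-indol-6-yl and 4-(trifluoromethyl)phenyl with measurable numbers throughout, whereas compound 4 shows that one aryl exchange here can leave the measurable range, and that tert-butyl in place of trifluoromethyl on the same phenyl is enough to do so.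

From the compounds shown here alone, the true size of these steps stays open, as a limit stands in place of a number for compound 4. Also open, going by these compounds, is where along the phenyl series the read-out is lost, for instance whether 4-isopropylphenyl, 4-methoxyphenyl or a phenyl bearing a dimethylamino group at the same carbon would keep a number or would also reach the limit.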